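Cytotoxicity in PC-3 cells across a shared piperidine-carboxamide core

The source may hold more compounds than are shown below. What is called first, only, known or untested is meant among the compounds shown, and "the series" means these compounds.

Measured compounds:
- compound 1, `O=C(Nc1cccc(N2CCCC2=O)c1)C1CCCN(C(=O)c2cc(C(F)(F)F)cc(C(F)(F)F)c2)C1`: 0%
- compound 2, `COCc1cccc(C(=O)N2CCCC(C(=O)Nc3ccc(Cl)cc3)C2)c1`: 0%

Compound 1 was tested in an ADME assay on PC-3 cells (Homo sapiens) for cytotoxicity, read by WST assay, tested at 100 uM (on this read-out higher numbers stand for more inhibition at the one concentration tested (going by the name of the read-out) and lower numbers for less inhibition), and gives 0%. Compound 2 differs from compound 1 in more than one place. In the same this assay compound 2 gives 0%. On the digits printed, compound 1 stands level with compound 2; the two values lie within the usual scatter of one another, so neither compound can be called more or less cytotoxic than the other.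

Compound 3, `O=C(Nc1cccc(Oc2nccc(C(F)(F)F)c2Cl)c1)C1CCCN(C(=O)c2cc(C(F)(F)F)cc(C(F)(F)F)c2)C1`, has not yet been measured. It differs from compound 1 in one place: (3-chloro-4-(trifluoromethyl)pyridin-2-yl)oxy in place of 2-oxopyrrolidin-1-yl on an aromatic carbon.

Within the data shown here, no step between measured compounds is available for this change, and both measured compounds sit at the floor of the read-out. Compound 3 is therefore expected to move little, and the step of a number 10 percentage points higher from compound 1 to compound 3 (within the scatter) is estimated to be small, upward if anything, though not clearly beyond the scatter. For compound 3 the estimate in this assay is 10%, with a range from 0% to 35%.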

Compound 3, a percentage reported as inhibition, at one concentration (the size of the read-out at that concentration, not a potency): 0%
For compound 3 the middle estimate is 10 percentage points above the measured one; the measured number falls inside the stated range.
By their numbers in this assay, from the lowest: compounds 1, 2 and 3 (each within the scatter of the next).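

In this assay, among these compounds, placing (3-chloro-4-(trifluoromethyl)pyridin-2-yl)oxy in place of 2-oxopyrrolidin-1-yl on an aromatic carbon gives no change at the digits printed from compound 1 to compound 3 (within the scatter), the first comparison here in which only one place differs. At this aromatic carbon, a group of 12 heavy atoms with a six-membered aromatic ring thus reads the same as a group of 6 heavy atoms with a five-membered non-aromatic ring, so this exchange produces no detectable cytotoxicity signal at the single concentration tested. Nothing available explains this outcome.

With this single step, and with every compound shown at the same value, the compounds do not reveal whether any group at this position can raise the read-out, for instance a primary amine or a carboxylic acid on the same aromatic carbon. They also leave open whether replacing the trifluoromethyl groups on the other side of the shared core with a longer alkyl chain or a nitrile would change the result in this assay at all.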